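The source may hold more compounds than are shown below. What is called first, only, known or untested is meant among the compounds shown, and "the series" means these compounds.

Measured compounds:
- compound 1 `O=C(COc1ccc(C(=O)/C=C/c2ccccc2)cc1)NO`: 620 nM
- compound 2 `NC(=O)N1N=C(c2ccccc2)CC1c1ccccc1OCC(=O)NO`: 18700 nM
- compound 3 `N#Cc1cccc(-c2cn(CCCCCCn3cccc(/C=C/C(=O)NO)c3=O)nn2)c1`: 600 nM

In a functional assay on HepG2 cells (Homo sapiens) for inhibition, read by MTT assay (a lower number here means a stronger inhibitor, a higher number a weaker inhibitor), compound 1 gives 620 nM, the second highest of the three numbers. Compound 3 sits within the scatter of it, so the two cannot be told apart; compound 2 lies well beyond the scatter, with the higher number of the set.

Compound 4 `O=C(COc1ccc(C(=O)/C=C/c2ccc(F)cc2)cc1)NO` differs from compound 1 by fluoro in place of hydrogen on an aromatic carbon, a change of one heavy atom on the outer ring of the shared core, with the rest untouched. Among the compounds with values here, no comparable pair of measured compounds is available, so there is no measured step to lean on. A change this small is expected to leave this assay close to where compound 1 stands: the step of a 1.1-fold lower number from compound 1 to compound 4 (0.05 log units; within the scatter) is estimated to fall within the scatter, with no clear direction. Compound 4 is therefore expected at 550 nM, in the range 250 nM to 1300 nM.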

Compound 4, half-maximal inhibitory concentration: 620 nM
Beside the measured number, compound 4's estimate is 1.1-fold (0.05 log units) below it, within the range that was stated.
By their numbers in this assay, from the lowest: compounds 3, 1 and 4 (each within the scatter of the next); then compound 2.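

Within the data shown here, the change from phenyl to 4-fluorophenyl gives no change at the digits printed from compound 1 to compound 4 (within the scatter) in this assay and is the first measured step. At this position, para to a large group on the outer aromatic ring, fluoro in place of hydrogen produces no readable shift. Nothing measured here explains this result.

Only this single small substituent has been compared at this carbon, so a larger group such as methoxy, an amine or a carboxylic acid could read differently. Going by these compounds, whether the flat result holds elsewhere on the shared core also remains open.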